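The source may report more compounds than this note shows. Statements on the series, on what has been measured and on what is new or still open speak of the compounds shown alone.

Among the measured compounds shown here, in a functional assay on HT-29 cells (Homo sapiens) for antiproliferative activity, read by sulforhodamine B assay, with a stated time of 48 h (on this read-out higher numbers stand for weaker inhibition and lower numbers for stronger inhibition), compound 1 (`COc1ccccc1OS(=O)(=O)c1ccc(N2CCN(C)C2=O)cc1`) gives 26000 nM as the only true number so far. Compound 2 (`CN1CCN(c2ccc(S(=O)(=O)Oc3ccc(F)cc3)cc2)C1=O`) stands at > 100000 nM as a limit of this assay and not a number. The change from compound 1 to compound 3 (`CCN1CCN(c2ccc(S(=O)(=O)Oc3ccccc3OC)cc2)C1=O`) is methyl in place of hydrogen on a saturated chain carbon bound to an amide-type nitrogen in a ring with methyl in place of hydrogen on a saturated chain carbon bound to an amide-type nitrogen in a ring, which turns methyl to ethyl. For the measured compounds named here, the only measured step is an at least 3.8-fold higher number from compound 1 to compound 2 (0.58 log units; beyond the scatter) (4-fluorophenyl in place of 2-methoxyphenyl on an oxygen). Going by the values given here, it lies at another place and bears on this change only loosely, and no step has been measured at the chain. No shift beyond the scatter is therefore expected in this assay. The expected size is a 1.3-fold lower number from compound 1 to compound 3 (0.11 log units; within the scatter) and thus within the scatter. Compound 3 is estimated at 20000 nM (range 6000 nM to 70000 nM).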

Compound 3, half-maximal inhibitory concentration: > 100000 nM
Compound 3 was reported as a limit; the forecaster's own chance of this, stated with the estimate: 10%; at least 5.0-fold (0.69 log units) between middle value and limit.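

In this assay the earlier step concerned only the group on the oxygen; the new step shows that the chain on the amide-type nitrogen also matters, with methyl to ethyl giving an at least 3.8-fold higher number from compound 1 to compound 3 (0.58 log units; beyond the scatter). The value of compound 3 is a limit of the assay and not a number. A single added methyl at this place, 3-methyl-2-oxoimidazolidin-1-yl to 3-ethyl-2-oxoimidazolidin-1-yl, is thus enough to take compound 3 out of the measurable range, and the true size of the step can be bounded from one side only: the limit of > 100000 nM in this assay, at which 2 of the 3 values shown sit.

Open, going by these compounds, is whether anything at this place gives a lower number than compound 1, for example hydrogen in place of the methyl, or a chain ending in a hydroxyl or an amine. Also open, on these data alone, is whether a longer chain such as propyl or a small ring such as cyclopropyl behaves as ethyl does.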